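Second fluoro on the aryl ring of compound 3

The source may hold more compounds than are shown below. What is called first, only, known or untested is meant among the compounds shown, and "the series" means these compounds.

Measured so far:
compound 1 `COc1ccccc1C1CCN(c2ccn3c(CC4CC4)nnc3c2Cl)CC1`: 345%
compound 2 `COc1ccc(F)cc1C1CCN(c2ccn3c(CC4CC4)nnc3c2Cl)CC1`: 283%
compound 3 `COc1c(F)cccc1C1CCN(c2ccn3c(CC4CC4)nnc3c2Cl)CC1`: 336%

In a functional assay on CHO cells for agonist activity at metabotropic glutamate receptor 2 (Homo sapiens), read by scintillation counting and GTPgammaS binding, with a stated time of 30 min (a higher number here means a larger maximal response, a lower number a smaller maximal response), compound 3 stands second highest of the three: the measurements show a number 9 percentage points lower from compound 1 to compound 3 (within the scatter) and a number 53 percentage points higher from compound 2 to compound 3 (beyond the scatter). Compound 4 `COc1ccc(F)c(F)c1C1CCN(c2ccn3c(CC4CC4)nnc3c2Cl)CC1` differs from compound 3 by 2,3-difluoro-6-methoxyphenyl in place of 3-fluoro-2-methoxyphenyl on a saturated ring carbon. Among the compounds with values here, two steps bear on this: adding one fluoro cost little in a number 9 percentage points lower from compound 1 to compound 3 (within the scatter) but a great deal in a number 62 percentage points lower from compound 1 to compound 2 (beyond the scatter). Since compound 4 carries two fluoro substituents on that ring, a drop in this assay beyond the scatter is expected, though less than the full fall seen for compound 2. Compound 4 is therefore estimated at 275% (range 195% to 345%), an expected step of a number 61 percentage points lower from compound 3 to compound 4 (beyond the scatter).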

Compound 4, largest response reached (Emax), in percent of the reference or control that the assay uses: 258%
The estimate for compound 4 lay 17 percentage points above the measured number, within the range that was stated.
By their numbers in this assay, from the lowest: compound 4; then compound 2; then compounds 3 and 1 (each within the scatter of the next).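

The 2,3-difluoro-6-methoxyphenyl group gives the lowest maximal response of the four compounds, with a number 87 percentage points lower from compound 1 to compound 4 (beyond the scatter), a number 78 percentage points lower from compound 3 to compound 4 (beyond the scatter) and a number 25 percentage points lower from compound 2 to compound 4 (beyond the scatter). Two fluoro substituents on this ring therefore take the response below that of either single fluoro compound. The effect of the same fluoro in place of hydrogen depends on what else the ring carries: the same change on two cores in this assay, a number 9 percentage points lower (within the scatter) from compound 1 to compound 3 and a number 25 percentage points lower (beyond the scatter) from compound 2 to compound 4, 16 percentage points apart, beyond the scatter of two such steps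

On these data alone, whether chloro or methyl in place of these fluoro substituents would lower the response as far remains open. So does the effect of hydroxy in place of methoxy.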